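A few compounds are considered here, and "the series" means these few. Any claim that something is new, unique, unknown or untested is made for them only; others in the source may bear on it.

Compound 1, `C/C(=C\CC/C(C)=C/CC[C@@H]1[C@@]2(C)CCC(=O)C(C)(C)[C@H]2CC[C@@]1(C)O)CC/C=C(\C)C(=O)OCc1cn(-c2ccc(C(F)(F)F)cc2)nn1`: in a functional assay on A549 cells (Homo sapiens) for antiproliferative activity, read by MTT assay, with a stated time of 48 h (on this read-out higher numbers stand for weaker inhibition and lower numbers for stronger inhibition), compound 1 reaches only the limit of the assay, > 150000 nM.
Compound 2, `C/C(=C\CC/C(C)=C/CC[C@@H]1[C@@]2(C)CCC(=O)C(C)(C)[C@H]2CC[C@@]1(C)O)CC/C=C(\C)C(=O)OCc1cn(C[C@@H]2O[C@H](n3ccc(=O)[nH]c3=O)[C@H]3OC(C)(C)O[C@H]32)nn1`: in this assay compound 2 gives 15300 nM.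
Compound 3, `C/C(=C\CC/C(C)=C/CC[C@@H]1[C@@]2(C)CCC(=O)C(C)(C)[C@H]2CC[C@@]1(C)O)CC/C=C(\C)C(=O)OCc1cn(-c2cccc(Cl)c2)nn1`: in this assay compound 3 gives 147000 nM.

Among the two numbers actually reported, compound 3 stands highest; its nearest neighbour is compound 2, which sits a long way lower, beyond the scatter, while compound 1 contributes only a limit, (the limit of > 150000 nM in this assay, at which 1 of the 3 values shown sits).

The step to compound 4, `C/C(=C\CC/C(C)=C/CC[C@@H]1[C@@]2(C)CCC(=O)C(C)(C)[C@H]2CC[C@@]1(C)O)CC/C=C(\C)C(=O)OCc1cn(-c2ccc(Cl)cc2)nn1`, is a small one: 4-chlorophenyl in place of 3-chlorophenyl on an aromatic nitrogen. Among the measured compounds shown here, only one measured step touches the group on that aromatic nitrogen, an at least 1.0-fold lower number from compound 1 to compound 3 (0.00 log units; that floor lies within the scatter), and it amounts to no movement at all, with compound 1 itself sitting at a limit rather than a number. That single step shows that exchanging one aryl group for another on this nitrogen did nothing visible in this assay, so no step beyond the scatter is expected here either.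

Compound 4 is therefore expected to lie close to compound 3, with an estimated step of a 1.0-fold higher number from compound 3 to compound 4 (0.01 log units; within the scatter). The estimate for compound 4 in this assay is 150000 nM, between 60000 nM and 300000 nM, with a real chance that the assay again reports only its limit.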

Compound 4, half-maximal inhibitory concentration: > 150000 nM
Compound 4: a limit, no number; the forecaster's own chance of this, stated with the estimate: 40%; the middle value sits exactly at the limit.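

Placing the chlorine elsewhere on the aryl group, as 4-chlorophenyl rather than 3-chlorophenyl, gives an at least 1.0-fold higher number from compound 3 to compound 4 (0.00 log units; that floor lies within the scatter), so in this assay the position of the chlorine on this ring brings no visible gain in inhibition, a point the earlier compounds could not show. From the compounds shown here alone, that step is only a floor, so how much weaker compound 4 may truly be stays unknown, and the step between compound 1 and compound 4 cannot be read at all. Neither of the steps among these chlorophenyl and trifluoromethylphenyl compounds that can be read goes beyond the scatter, and the limit now recurs among them: the limit of > 150000 nM in this assay, at which 2 of the 4 values shown sit.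

Among the compounds shown, only compound 2 gives a value far from the rest, 15300 nM, and its group on the nitrogen is not an aryl group, which leaves open which part of that group matters. Going by these compounds, it also remains open whether an amine or a carboxylic acid on the phenyl ring, or an unsubstituted phenyl, would bring the number down in this assay.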